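The source may hold more compounds than are shown below. What is called first, only, known or untested is meant among the compounds shown, and "the series" means these compounds.

Three compounds share one core and have each been tested in a functional assay on MCF7 cells (Homo sapiens) for antiproliferative activity, read by MTT assay, with a stated time of 72 h; a lower number here means a stronger inhibitor, a higher number a weaker inhibitor. Compound 1 `COc1cc2ncnc(N3CCc4ccccc43)c2cc1NC(=O)/C=C/CN1CCCCC1` gives 1680 nM in this assay. Compound 2 `COc1cc2ncnc(N3CCc4ccccc43)c2cc1NC(=O)/C=C/CN1CCN(C)CC1` carries a single change relative to compound 1, namely (4-methylpiperazin-1-yl in place of piperidin-1-yl on a saturated chain carbon bound to a double-bonded chain carbon), and that change brought a 3.8-fold higher number from compound 1 to compound 2 (0.58 log units; beyond the scatter). In this assay compound 2 gives 6430 nM. Compound 3 `O=C(/C=C/CN1CCCCC1)Nc1cc2c(N3CCc4ccccc43)ncnc2cc1O[C@@H]1CCOC1` differs from compound 1 at another spot, (oxolan-3-yl in place of methyl on an oxygen on an aromatic ring), and in this assay compound 3 gives 1890 nM, so that a 1.1-fold higher number from compound 1 to compound 3 (0.05 log units; within the scatter).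

Compound 4 `CN1CCN(C/C=C/C(=O)Nc2cc3c(N4CCc5ccccc54)ncnc3cc2O[C@@H]2CCOC2)CC1` has not yet been measured. It stands to compound 3 as compound 2 stands to compound 1: the change is 4-methylpiperazin-1-yl in place of piperidin-1-yl on a saturated chain carbon bound to a double-bonded chain carbon, and its place is described in the same words as before, so it is the same change, made on a core that differs only by oxolan-3-yl in place of methyl on an oxygen on an aromatic ring. Because the step of a 1.1-fold higher number from compound 1 to compound 3 (0.05 log units; within the scatter) shows the two cores sitting close together in this assay, the new change is expected to repeat the earlier weakening. Compound 4 is therefore expected to give 7000 nM, within a range from 3500 nM to 14000 nM. The expected step of a 3.7-fold higher number from compound 3 to compound 4 (0.57 log units; beyond the scatter) rests on the measured step of a 3.8-fold higher number from compound 1 to compound 2 (0.58 log units; beyond the scatter).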

Compound 4, half-maximal inhibitory concentration: 5350 nM
The estimate for compound 4 lay 1.3-fold (0.12 log units) above the measured number; the range from low to high includes it.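

In this assay, putting 4-methylpiperazin-1-yl in place of piperidin-1-yl on the core of compound 3 gives a 2.8-fold higher number from compound 3 to compound 4 (0.45 log units; beyond the scatter), and this weakening carries over from the core of compound 1 at much the same size: the same change on two cores in this assay, a 3.8-fold higher number (0.58 log units; beyond the scatter) from compound 1 to compound 2 and a 2.8-fold higher number (0.45 log units; beyond the scatter) from compound 3 to compound 4, 1.4-fold (0.13 log units) apart, within the scatter of two such steps

The other change, oxolan-3-yl in place of methyl on an oxygen on an aromatic ring, gives a 1.2-fold lower number from compound 2 to compound 4 (0.08 log units; within the scatter), so it makes no measurable difference with either ring at the chain end: the same change on two cores in this assay, a 1.1-fold higher number (0.05 log units; within the scatter) from compound 1 to compound 3 and a 1.2-fold lower number (0.08 log units; within the scatter) from compound 2 to compound 4, 1.4-fold (0.13 log units) apart, within the scatter of two such steps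

Across these four compounds the two changes therefore behave independently, so the effect of one can be carried to the core bearing the other, but this rests on only two cores in a single cell assay and does not explain why the piperidin-1-yl compounds give the lower numbers.

The compounds shown leave open whether another amine on the same saturated chain carbon, such as morpholin-4-yl or dimethylamino, would fit the same picture. They also leave open whether a longer chain on the aromatic oxygen, such as a 2-methoxyethyl group, would stay as close to methyl as oxolan-3-yl does.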